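This account rests on a few compounds, and the source may have more. Where it says the series, first, only, none or still open, it means among the compounds named here.

Of the compounds shown here, three built on one shared core have been measured in an ADME assay on SK-OV-3 cells (Homo sapiens) for cytotoxicity, read by sulforhodamine B assay, with a stated time of 48 h, tested at 10 uM; on this read-out higher numbers stand for more inhibition at the one concentration tested (going by the name of the read-out) and lower numbers for less inhibition. Compound 1 `CCCCCCc1cn(C(c2ccccc2)c2cc3cc(Br)ccc3nc2OC)nn1` gives 7.17% in this assay. Compound 2 `COc1nc2ccc(Br)cc2cc1C(c1ccccc1)n1cc(-c2ccccc2)nn1` gives 13.7% in this assay. Compound 3 `CCCc1cn(C(c2ccccc2)c2cc3cc(Br)ccc3nc2OC)nn1` gives 11.2% in this assay. Compound 2 holds the highest of the three numbers, but every gap is small: a number 6.5 percentage points higher from compound 1 to compound 2 (within the scatter), a number 2.5 percentage points lower from compound 2 to compound 3 (within the scatter), and a number 4 percentage points higher from compound 1 to compound 3 (within the scatter). All three steps stay within the scatter, so the three compounds cannot be told apart on these numbers.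

Compound 4 `COc1nc2ccc(Br)cc2cc1C(c1ccccc1)n1cc(-c2ccccc2C(F)(F)F)nn1` is the next compound to be tested. Its difference from compound 2 is trifluoromethyl in place of hydrogen on an aromatic carbon Seen one bond further out, phenyl becomes 2-(trifluoromethyl)phenyl.

Going by the values given here, two measured steps touch the same part of the molecule: the step from compound 1 to compound 2 swapped hexyl for phenyl on that aromatic carbon, and the step from compound 2 to compound 3 swapped phenyl for propyl there. Both stayed within the scatter. Among the compounds with values here, no measured step adds a trifluoromethyl anywhere, so there is no direct guide for that group. Given how little the group on this carbon has moved the read-out, compound 4 is expected to sit close to compound 2, with an estimated step of a number 0.3 percentage points higher from compound 2 to compound 4 (within the scatter). Compound 4 is therefore estimated at 14%, within a range from 3% to 28%.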

Compound 4, a percentage reported as inhibition, at one concentration (the size of the read-out at that concentration, not a potency): 9.55%
Compound 4: the middle estimate sits 4.5 percentage points above what was measured, and the stated range covers the measured number.
By their numbers in this assay, from the lowest: compounds 1, 4, 3 and 2 (each within the scatter of the next).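

Adding a trifluoromethyl to the phenyl ring of compound 2, on an aromatic carbon ortho to a large group, gives the first reading for a substituent on that ring in this assay: the result is a number 4.2 percentage points lower from compound 2 to compound 4 (within the scatter), so this change cannot be told apart from no change at all. The comparisons with the two compounds carrying open chains at this position show the same thing, with a number 1.7 percentage points lower from compound 3 to compound 4 (within the scatter) and a number 2.4 percentage points higher from compound 1 to compound 4 (within the scatter), so 2-(trifluoromethyl)phenyl now stands with phenyl, propyl and hexyl among groups that this read-out does not separate. Nothing available here explains why the numbers stay so close together.

As far as these compounds go, it remains open whether any group at this position can move the read-out beyond the scatter, for instance an amine or a carboxylic acid on the phenyl ring, or a much longer chain in place of hexyl. Going by these compounds alone, it is also unknown whether a trifluoromethyl placed elsewhere on the same ring would read any differently from the one in compound 4.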